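The source may report more compounds than this note shows. Statements on the series, on what has been measured and on what is new or still open speak of the compounds shown alone.

Measured in a functional assay on Caco-2 cells (Homo sapiens) for antiproliferative activity, with a stated time of 48 h; on this read-out lower numbers stand for stronger inhibition and higher numbers for weaker inhibition (all three entries are limits):
compound 1 `CCN(CC)c1ccc(-c2cccc(OC)c2)nn1` – > 25000 nM
compound 2 `CCN(CC)c1ccc(-c2cccc(C#N)c2)nn1` – > 25000 nM
compound 3 `CCOC(=O)c1cccc(-c2ccc(N(CC)CC)nn2)c1` – > 25000 nM

Compound 2 gives > 25000 nM as a limit and not a number, so it has no readable place within the series. The whole set looks the same, as the limit of > 25000 nM in this assay, at which 3 of the 3 values shown sit, shows.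

Three measured steps exist: a step that the two limits leave unreadable from compound 1 to compound 2 and a step that the two limits leave unreadable from compound 1 to compound 3 and a step that the two limits leave unreadable from compound 2 to compound 3. None of them has a readable size, and all three exchange a group other than diethylamino.

Compound 4 `CCCCOc1ccc(-c2cccc(C#N)c2)nn1` keeps cyano and carries butoxy in place of diethylamino on an aromatic carbon, next to the ring nitrogen: butoxy in place of diethylamino on an aromatic carbon. Among the compounds with values here, no measured step covers this exchange, so the series gives neither a size nor a direction for it in this assay. No clear step is expected, and another limit is the likeliest report. This expectation rests on compound 2, whose > 25000 nM is a limit.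

The expected change is a number no higher from compound 2 to compound 4 (the limit leaves the size open) and it remains uncertain. For compound 4 the estimated value is 25000 nM with an estimated range of 8000 nM to 60000 nM.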

Compound 4, half-maximal inhibitory concentration: > 25000 nM
Compound 4: only a limit was reported; the forecaster's own chance of this, stated with the estimate: 70%; the middle value sits exactly at the limit.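

In this assay compound 4 gives > 25000 nM, a limit and not a number. Compound 2 is also reported only as a limit, so no new step can be read between compound 2 and compound 4. The compounds shown leave open whether butoxy and diethylamino differ at all on this read-out, and where any of the four would fall as a number: the limit of > 25000 nM in this assay, at which 4 of the 4 values shown sit.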